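The source may report more compounds than this note shows. Statements on the series, on what has been measured and on what is new or still open speak of the compounds shown alone.

Compound 1 `CN(CC(C)(C)C)CC1(O)CCN(CCCc2c[nH]c3ccc(-n4cnnc4)cc23)CC1`: 1.8 nM
Compound 2 `Cc1ccccc1CNCC1(O)CCN(CCCc2c[nH]c3ccc(-n4cnnc4)cc23)CC1`: 4 nM
Compound 3 `CN(Cc1ccccc1)CC1(O)CCN(CCCc2c[nH]c3ccc(-n4cnnc4)cc23)CC1`: 1.2 nM

In an assay on CHO cells with 5-hydroxytryptamine receptor 1D (Homo sapiens) as the target (a lower number here means a stronger inhibitor, a higher number a weaker inhibitor), compound 3 holds the lowest of the three numbers; compound 1 lies nearest to it, within the scatter, while compound 2 stands furthest, beyond it. Compound 4 `CC1(C)CCCN(CC2(O)CCN(CCCc3c[nH]c4ccc(-n5cnnc5)cc34)CC2)C1` differs from compound 3 by 3,3-dimethylpiperidin-1-yl in place of benzyl(methyl)amino on a saturated chain carbon bound to a saturated ring carbon. The measured step that bears most directly on this is a 1.5-fold lower number from compound 1 to compound 3 (0.18 log units; within the scatter), where phenyl in place of tert-butyl on the amine-bound carbon left the number within the scatter. The other relevant step, a 3.3-fold lower number from compound 2 to compound 3 (0.52 log units; beyond the scatter), was modest and concerned a methyl on the amine nitrogen; compound 4 keeps a tertiary amine, as compounds 1 and 3 do. The expected step is therefore a 1.7-fold higher number from compound 3 to compound 4 (0.22 log units; within the scatter). Compound 4 is estimated at 2 nM, expected between 0.8 nM and 5 nM.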

Compound 4, half-maximal inhibitory concentration: 0.65 nM
The estimate for compound 4 lay 3.1-fold (0.49 log units) above the measured number; the whole stated range lies above it.
By their numbers in this assay, from the lowest: compounds 4, 3 and 1 (each within the scatter of the next, the first and the last beyond it); then compound 2.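

In this assay, a non-aromatic ring amine can take the place of benzyl(methyl)amino on the saturated chain carbon bound to a saturated ring carbon: 3,3-dimethylpiperidin-1-yl gives a 1.8-fold lower number from compound 3 to compound 4 (0.27 log units; within the scatter), so the six-membered aromatic ring of carbon only is not required here. The same group also gives a 2.8-fold lower number from compound 1 to compound 4 (0.44 log units; beyond the scatter) and a 6.2-fold lower number from compound 2 to compound 4 (0.79 log units; beyond the scatter), both beyond the scatter. No evidence here accounts for these steps. Open, on these data alone, is how plain piperidin-1-yl, without the two methyl groups, or morpholin-4-yl would compare at this position.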